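From 2,4-difluorobenzyl to 4-methylbenzyl: what to expect

The source may hold more compounds than are shown below. What is called first, only, known or untested is meant among the compounds shown, and "the series" means these compounds.

Measured in a toxicity assay on NIH3T3 cells (Mus musculus) for cytotoxicity, read by resazurin assay; a higher number here means that more compound is needed for the effect, a lower number that less compound is needed:
- Compound 1 `COC(=O)c1ccc(NCc2cncn2Cc2ccc(Cl)cc2)cc1-c1ccccc1`: 25000 nM
- Compound 2 `COC(=O)c1ccc(NCc2cncn2Cc2ccc(F)cc2F)cc1-c1ccccc1`: > 1000 nM (a limit)

Compound 2 has only a limit, > 1000 nM, and no exact number. Compound 3 `COC(=O)c1ccc(NCc2cncn2Cc2ccc(C)cc2)cc1-c1ccccc1` changes one group of compound 2: 4-methylphenyl in place of 2,4-difluorophenyl on a saturated chain carbon bound to an aromatic nitrogen. This puts 4-methylphenyl in place of 2,4-difluorophenyl on a saturated chain carbon bound to an aromatic nitrogen. Within the data shown here, the one measured step at this place is a step that the limit leaves unreadable from compound 1 to compound 2. It therefore gives no size to carry over, and the direction stays uncertain. Among the measured compounds shown here, the only exact number comes from compound 1, at 25000 nM, so the expectation for this assay stays close to that value, with a wide range. The expected step is a step that the limit leaves unreadable from compound 2 to compound 3, and it is only an estimate. The estimated value for compound 3 is 20000 nM, with an expected range from 5000 nM to 60000 nM.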

Compound 3, half-maximal effective concentration: 50000 nM
For compound 3 the middle estimate is 2.5-fold (0.40 log units) below the measured one; the measured number falls inside the stated range.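

In this assay, methyl in place of chloro on an aromatic carbon gives a 2.0-fold higher number from compound 1 to compound 3 (0.30 log units; within the scatter). Among these compounds, this is the first readable comparison at this place, and it shows that compound 1 and compound 3 cannot be told apart here, so this exchange does not shift the number beyond the usual scatter. Compound 2 carries only a limit, so the steps that involve it cannot be read: the limit of > 1000 nM in this assay, at which 1 of the 3 values shown sits.

On these data alone, whether the 2,4-difluorobenzyl group of compound 2 behaves like the groups in compound 1 and compound 3 therefore stays open. The compounds shown also leave open what a group of a different kind, such as an amine or a carboxylic acid in place of the methyl, would do to the number in this assay.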